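Bromo for hydrogen on the pendant phenyl of compound 2

The source may hold more compounds than are shown below. What is called first, only, known or untested is meant among the compounds shown, and "the series" means these compounds.

Three members of the series have numbers in a functional assay on C6 cells (Rattus norvegicus) for cytotoxicity, read by MTT assay, with a stated time of 24 h, tested at 25 ug/mL; on this read-out higher numbers stand for a weaker effect at the one concentration tested and lower numbers for a stronger effect. Compound 1 `Cn1nnnc1SCC(=O)N/N=c1/scc(-c2ccccc2)n1-c1ccccc1` gives 64.2%. Compound 2 `O=C(CSc1nnnn1-c1ccccc1)N/N=c1/scc(-c2ccccc2)n1-c1ccccc1` gives 42.5%, and compound 3 `COc1ccc(-c2cs/c(=N/NC(=O)CSc3nnc(C)s3)n2-c2ccccc2)cc1` gives 42.6%. Compound 2 thus carries the lowest of the three numbers: its number lies well below that of compound 1, with a number 21.7 percentage points lower from compound 1 to compound 2 (beyond the scatter), while its gap to compound 3 falls within the scatter, so no order between compound 2 and compound 3 can be read.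

Compound 4 `O=C(CSc1nnnn1-c1ccccc1)N/N=c1/scc(-c2ccc(Br)cc2)n1-c1ccccc1` is not yet measured. It differs from compound 2 by bromo in place of hydrogen on an aromatic carbon. Within the data shown here, no measured step touches this change: the single step between measured neighbours swaps a methyl for a phenyl on the aromatic nitrogen, and compound 3 differs from compound 2 in more than one place, so its value is only a second point near that of compound 2. Among the measured compounds shown here, with no bearing step, a step within the scatter is the working expectation. For compound 4 the expected step is a number 0.5 percentage points lower from compound 2 to compound 4 (within the scatter). Compound 4 is therefore estimated at 42%, between 25% and 60%.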

Compound 4, a percentage reported as activity, at one concentration (the size of the read-out at that concentration, not a potency): 47.9%
Estimate against measurement, compound 4: 5.9 percentage points below; measured number inside the range.
By their numbers in this assay, from the lowest: compounds 2, 3 and 4 (each within the scatter of the next); then compound 1.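

Moving from phenyl to 4-bromophenyl on the core of compound 2 gives the first reading at this position in this assay, with a number 5.4 percentage points higher from compound 2 to compound 4 (within the scatter). Among these compounds, at this place on the six-membered aromatic ring, a single bromine atom therefore leaves no readable change, whereas the only earlier step, a number 21.7 percentage points lower from compound 1 to compound 2 (beyond the scatter), came from the group on the aromatic nitrogen. Nothing available accounts for this outcome.

From the compounds shown here alone, whether an amine or a carboxylic acid at this same place would move the number beyond the scatter remains open. Also open, going by these compounds, is whether bromo in place of hydrogen would give a similar step on the core of compound 1, which carries methyl rather than phenyl on the aromatic nitrogen.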